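A few compounds are considered here, and "the series" means these few. Any claim that something is new, unique, unknown or untested is made for them only; others in the source may bear on it.

Of the compounds shown here, three built on one shared core have so far been tested in an ADME assay on isolated protein for inhibition of Amine oxidase [flavin-containing] A (Homo sapiens), read by fluorescence and Amplex Red, with stated times of 15 min and 20 min; a higher number here means a weaker inhibitor, a lower number a stronger inhibitor. Compound 2 `C#CCN(CCCOc1ccc2ccc(=O)oc2c1)Cc1ccc(C)cc1` gives 116000 nM. Compound 3 `C#CCN(CCCCOc1ccc2ccc(=O)oc2c1)Cc1ccc(C)cc1` gives 94500 nM, and compound 1 `C#CCN(CCCCOc1ccc2ccc(=O)oc2c1)Cc1cccc(OC)c1` gives 78600 nM. The three numbers all lie within the usual scatter of one another, so on these data compound 2 is not set apart from compound 3 or from compound 1. Going by the values given here, the only single-point comparison among them, a 1.2-fold higher number from compound 1 to compound 3 (0.08 log units; within the scatter), likewise stays within the scatter.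

Compound 4 `C#CCN(CCCOc1ccc2ccc(=O)oc2c1)Cc1ccc(C(C)C)cc1` has not yet been measured. It differs from compound 2 by isopropyl in place of methyl on an aromatic carbon. Among the compounds with values here, no measured pair shows this exact exchange, and the one measured change on the same ring, a 1.2-fold higher number from compound 1 to compound 3 (0.08 log units; within the scatter), was flat. The gap between compound 2 and compound 3, where only the chain length differs, is also within the scatter. On that basis compound 4 is expected to stay close to compound 2, with the step from compound 2 to compound 4 estimated as a 1.2-fold lower number from compound 2 to compound 4 (0.06 log units; within the scatter), a change not expected to exceed the scatter. The estimate for compound 4 in this assay is 100000 nM, within a range from 40000 nM to 250000 nM.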

Compound 4, half-maximal inhibitory concentration: 77400 nM
For compound 4 the middle estimate is 1.3-fold (0.11 log units) above the measured one; measured number inside the range.
By their numbers in this assay, from the lowest: compounds 4, 1, 3 and 2 (each within the scatter of the next).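

In this assay, isopropyl in place of methyl is a 1.5-fold lower number from compound 2 to compound 4 (0.18 log units; within the scatter). The group at this place, para to a large group, thus grows from 1 heavy atom to 3 without moving the reading beyond the scatter. Going by these compounds alone, this step isolates a change in the size of the carbon group at one fixed place on the ring, whereas the earlier step on this ring, a 1.2-fold higher number from compound 1 to compound 3 (0.08 log units; within the scatter), changed both the group and its place, so the two results together suggest only that these particular changes leave the reading within the scatter.

Going by these compounds, it remains open whether any group at this place can shift the reading beyond the scatter, since a carboxylic acid or an amine would differ in kind from the methyl and isopropyl compared here. On these data alone, it is also open whether isopropyl in place of methyl would give a similar step on the longer chain of compound 3. No supporting information bears on this result, so it rests on the assay readings alone.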